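A few compounds are considered here, and "the series" means these few. Any claim that something is new, unique, unknown or untested is made for them only; others in the source may bear on it.

Of the compounds shown here, three that share one core have been measured in an assay on cells for agonist activity at ecdysone receptor (Bombyx mori), read by a luciferase reporter, with a stated time of 24 h; on this read-out higher numbers stand for an effect only at larger amounts of compound and lower numbers for an effect already at smaller amounts. Compound 1 `Cc1ccccc1C(=O)N(NC(=O)c1ccccc1)C(C)(C)C` gives 224 nM in this assay. Compound 2 `COc1ccccc1C(=O)N(NC(=O)c1ccccc1)C(C)(C)C` gives 525 nM in this assay. Compound 3 `CC(C)(C)N(NC(=O)c1cccc(C#N)c1)C(=O)c1ccccc1Cl` gives 955 nM in this assay, the highest of the three numbers: against compound 2 the two values lie within the usual scatter of this kind of measurement, while against compound 1 the gap is beyond it. Going by the values given here, the only step between measured compounds that differ in one place is a 2.3-fold higher number from compound 1 to compound 2 (0.37 log units; beyond the scatter), and it concerns the ring carrying the methyl or methoxy group, not the ring that changes next.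

Compound 4 `CCc1ccc(C(=O)NN(C(=O)c2ccccc2Cl)C(C)(C)C)cc1` has not yet been measured. It differs from compound 3 in one place: 4-ethylphenyl in place of 3-cyanophenyl on a carbonyl carbon. Among the compounds with values here, no measured step touches this ring on the carbonyl carbon, so the record offers no direct guide to the size or direction of the change; the one known step, a 2.3-fold higher number from compound 1 to compound 2 (0.37 log units; beyond the scatter), is modest and sits elsewhere. The author therefore expects at most a modest step, leaning toward a lower number because compound 3 already gives the highest value at 955 nM. Compound 4 is estimated at 350 nM in this assay, within a range from 80 nM to 1500 nM. This estimate corresponds to an expected step of a 2.7-fold lower number from compound 3 to compound 4 (0.44 log units; beyond the scatter).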

Compound 4, half-maximal effective concentration: 5.75 nM
Beside the measured number, compound 4's estimate is 61-fold (1.78 log units) above it; the whole stated range lies above it.
By their numbers in this assay, from the lowest: compound 4; then compound 1; then compounds 2 and 3 (each within the scatter of the next).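

Going by these compounds alone, the ring on the carbonyl carbon whose other neighbour is the amide-type nitrogen proves far more sensitive than the earlier record could show: in this assay the change gives a 170-fold lower number from compound 3 to compound 4 (2.22 log units; beyond the scatter), whereas the only earlier step, on the other ring, was a 2.3-fold higher number from compound 1 to compound 2 (0.37 log units; beyond the scatter). This large step comes with no change in the heavy-atom count of the group, since 3-cyanophenyl and 4-ethylphenyl match on that count, so size measured in this way does not separate them; what differs is that the nitrile, with its triple bond and hydrogen-bond acceptor, leaves, an ethyl group enters, and the substituent's number in the group's name changes. No measurement is available that accounts for the size of this step.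

The compounds shown cannot tell whether the gain follows from losing the nitrile, gaining the ethyl group or the different substitution on the ring, a question that 4-cyanophenyl and 3-ethylphenyl at this place would bear on directly. As far as these compounds go, it also remains open how a longer chain such as 4-propylphenyl or 4-butylphenyl, or an amine or a carboxylic acid on this ring, would behave, and whether the step would hold with methyl or methoxy on the other ring.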